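Three limits and one untested group

The compounds below may be only part of what the source reports. "The series", "measured", "known", "first", "only" and "open" are said of these compounds alone.

Compound 1 `Cc1c(-c2ccc(Cc3ccc(C(C)(O)C(F)(F)F)cc3)cc2)[nH]c2cccc(F)c2c1=O`: > 2500 nM, a limit.
Compound 2 `Cc1c(-c2ccc(Cc3ccc(S(=O)(=O)C(F)(F)F)cc3)cc2)[nH]c2cccc(F)c2c1=O`: > 2500 nM, a limit.
Compound 3 `Cc1c(-c2ccc(Cc3ccc(S(=N)(=O)C(F)(F)F)cc3)cc2)[nH]c2cccc(F)c2c1=O`: > 10000 nM, a limit.

None of these three compounds gave an actual number in an ADME assay on Huh7.5.1 cells (Homo sapiens) for cytotoxicity, read by WST assay, with a stated time of 48 h; on this read-out higher numbers stand for lower toxicity in this test and lower numbers for higher toxicity in this test. Compound 3 alone sits at the limit of > 10000 nM in this assay, at which 1 of the 3 values shown sits. Compound 1 and compound 2 sit at the limit of > 2500 nM in this assay, at which 2 of the 3 values shown sit.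

The next compound, compound 4 `Cc1c(-c2ccc(Cc3ccc(OC(F)F)cc3)cc2)[nH]c2cccc(F)c2c1=O`, keeps the shared core and exchanges a single group: a group of 4 heavy atoms (1 carbon, 1 oxygen, 2 fluorine; no ring) in place of a group of 7 heavy atoms (1 carbon, 1 nitrogen, 1 oxygen, 3 fluorine, 1 sulfur; no ring), on an aromatic carbon. The new group is difluoromethoxy, on the same aromatic carbon.

The measured steps that bear on this swap are changes at that same place. They are a step that the two limits leave unreadable from compound 1 to compound 3, a step that the two limits leave unreadable from compound 2 to compound 3 and a step that the two limits leave unreadable from compound 1 to compound 2. None of them has a readable size, so they point in no direction. All they show is that three different groups at this place gave limits rather than numbers. No step beyond the scatter is therefore expected, and compound 4 will quite likely report only a limit in this assay too. The expected change is a number no higher from compound 3 to compound 4 (the limit leaves the size open). For compound 4 the estimated value is 10000 nM, with an expected range from 3000 nM to 30000 nM.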

Compound 4, half-maximal cytotoxic concentration: > 5000 nM
Compound 4 was reported as a limit (the forecaster's own chance of this, stated with the estimate: 75%); the middle value does not contradict the limit.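

Compound 4, like compound 1, compound 2 and compound 3, gives only a limit in this assay, so the steps from each of those three compounds to compound 4 cannot be read. The compounds shown leave open whether the group at this place changes the half-maximal cytotoxic concentration at all, and what that concentration actually is for any of the four compounds.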